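This account rests on a few compounds, and the source may have more. Where it says the series, first, only, none or still open, it means among the compounds named here.

Values in a functional assay on THP-1 cells (Homo sapiens) for cytotoxicity, read by MTT assay, with a stated time of 24 h; on this read-out higher numbers stand for weaker inhibition and lower numbers for stronger inhibition
- compound 1 `CN1C/C(=C\c2ccc(C#N)cc2)C(=O)/C(=C/c2ccccc2F)C1` gives 810 nM
- compound 2 `CN1C/C(=C\c2ccc(F)cc2)C(=O)/C(=C/c2ccc(C#N)cc2)C1` gives 5030 nM
- compound 3 `CN1C/C(=C\c2ccc(Cl)cc2)C(=O)/C(=C/c2ccc(C#N)cc2)C1` gives 3180 nM

Compound 3, at 3180 nM, holds the second highest of the three numbers. It cannot be separated from compound 2, given a 1.6-fold lower number from compound 2 to compound 3 (0.20 log units; within the scatter), but it stands clearly apart from compound 1, given a 3.9-fold higher number from compound 1 to compound 3 (0.59 log units; beyond the scatter).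

The next step leads to compound 4 `CN1C/C(=C\c2ccc(Br)cc2)C(=O)/C(=C/c2ccc(C#N)cc2)C1`, with the change (bromo in place of chloro on an aromatic carbon), that is, bromo in place of chloro on an aromatic carbon, para to a large group. Within the data shown here, the closest precedent is the halogen exchange at this place, a 1.6-fold lower number from compound 2 to compound 3 (0.20 log units; within the scatter). The larger 6.2-fold higher number from compound 1 to compound 2 (0.79 log units; beyond the scatter) replaces 2-fluorophenyl and is a different kind of change, so it bears only weakly here, as does a 3.9-fold higher number from compound 1 to compound 3 (0.59 log units; beyond the scatter). Among the measured compounds shown here, no bromo compound has been measured yet.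

No step beyond the scatter is therefore expected in this assay. The estimated change is a 1.1-fold lower number from compound 3 to compound 4 (0.06 log units; within the scatter), which would stay within the scatter. Compound 4 is expected at 2800 nM, with an estimated range of 1400 nM to 5500 nM.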

Compound 4, half-maximal inhibitory concentration: 4400 nM
Estimate against measurement, compound 4: 1.6-fold (0.20 log units) below, and the stated range covers the measured number.
By their numbers in this assay, from the lowest: compound 1; then compounds 3, 4 and 2 (each within the scatter of the next).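

In this assay, the halogen on an aromatic carbon, para to a large group, now covers fluoro, chloro and bromo with no step beyond the scatter: a 1.4-fold higher number from compound 3 to compound 4 (0.14 log units; within the scatter), and a 1.1-fold lower number from compound 2 to compound 4 (0.06 log units; within the scatter). The 4-bromophenyl compound also stays apart from the 2-fluorophenyl compound, a 5.4-fold higher number from compound 1 to compound 4 (0.73 log units; beyond the scatter), so all three 4-halophenyl compounds now show this separation, with none going against it. No supporting data bear on why the three halogens cannot be separated or why compound 1 stands apart.

Still open, from the compounds shown here alone, is whether a group that is not a halogen at this place, such as methoxy, an amine or a carboxylic acid, would separate from the three halogens. Also open, going by these compounds, is whether chloro or bromo in place of the fluoro of 2-fluorophenyl would stay close to compound 1 at 810 nM.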